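A few compounds are considered here, and "the series" means these few. Any claim that something is new, unique, unknown or untested is made for them only; others in the source may bear on it.

Compound 1, `O=S(=O)(c1ccc(O)c2ncccc12)C1CCCC1`, gives 26 mL/min/kg.
Compound 2, `O=S(=O)(c1ccc(C(F)(F)F)cc1)c1cc(F)c(O)c2ncccc12`, gives 13 mL/min/kg.
Compound 3, `O=S(=O)(c1ccc(F)cc1)c1cc(Cl)c(O)c2ncccc12`, gives 0.31 mL/min/kg.

In an ADME assay on the whole organism (plasma) for pharmacokinetics, with Rattus norvegicus as the target (on this read-out higher numbers stand for fast clearance and lower numbers for slow clearance), compound 2 stands second highest of the three numbers. Compound 1 sits nearest, a step above it that lies within the scatter, while compound 3 sits far below it, a gap well beyond the scatter. Compound 4, `Cc1ccc(S(=O)(=O)c2cc(F)c(O)c3ncccc23)cc1`, differs from compound 2 in a single place: methyl in place of trifluoromethyl on an aromatic carbon. Among the measured compounds shown here, no measured pair shows this change, so its size is uncertain; a modest move toward faster clearance, possibly no larger than the scatter, is expected, a 1.4-fold higher number from compound 2 to compound 4 (0.14 log units; within the scatter). Compound 4 is therefore estimated to give about 18 mL/min/kg in this assay, with a range from 7 mL/min/kg to 45 mL/min/kg.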

Compound 4, clearance: 27 mL/min/kg
The estimate for compound 4 lay 1.5-fold (0.18 log units) below the measured number, and the stated range covers the measured number.
By their numbers in this assay, from the lowest: compound 3; then compounds 2, 1 and 4 (each within the scatter of the next, the first and the last beyond it).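

In this assay, among the compounds shown here, methyl in place of trifluoromethyl on an aromatic carbon para to a large group gives a 2.1-fold higher number from compound 2 to compound 4 (0.32 log units; beyond the scatter), the first comparison here of compounds that differ in one place. It shows that this position can shift clearance, though only modestly, with methyl carrying the higher number. No measurement available here accounts for the step. Going by these compounds, whether a nitrile or a methoxy group in this place would raise or lower the number remains open, as does whether the same change gives a similar step on other compounds.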